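A few compounds are considered here, and "the series" means these few. Any claim that something is new, unique, unknown or untested is made for them only; others in the source may bear on it.

In an ADME assay on MT4 cells (Homo sapiens) for cytotoxicity, read by MTT assay, with a stated time of 96 h (a lower number here means that less compound is tolerated, a higher number that more compound is tolerated), compound 1 (`CN(C)CCCN(/N=N/c1ccccc1)c1cccc(C(F)(F)F)c1`) gives 14000 nM, at the low end of the three numbers in the series. Compound 3 (`CN(C)CCCN(/N=N/c1cc(F)ccc1F)c1cccc(C(F)(F)F)c1`) gives 16000 nM, and the measured step is a 1.1-fold higher number from compound 1 to compound 3 (0.06 log units; within the scatter), so the two stand level. Compound 2 (`CN(C)CCCN(/N=N/c1ccccc1)c1ccccc1`) gives 33000 nM, and the measured step is a 2.4-fold higher number from compound 1 to compound 2 (0.37 log units; beyond the scatter), a modest one.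

The next comparison is with compound 4 (`FC(F)(F)c1cccc(N(C[C@@H]2CCCN3CCCC[C@H]23)/N=N/c2ccccc2)c1`), which carries a different change: a group of 10 heavy atoms (9 carbon, 1 nitrogen; 2 six-membered non-aromatic rings with 1 hetero atom each) in place of a group of 5 heavy atoms (4 carbon, 1 nitrogen; no ring), on a saturated chain carbon bound to a nitrogen on an aromatic ring. Within the data shown here, neither measured step alters the 2-(dimethylamino)ethyl group, and no measured compound carries the entering group, so the series offers no direct measure of this change. Among the measured compounds shown here, the only guide to size is the larger measured step, a 2.4-fold higher number from compound 1 to compound 2 (0.37 log units; beyond the scatter). A modest step of similar size is expected in this assay, towards a lower number, although the direction is a weak expectation and a result within the scatter of compound 1 would not be surprising.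

The expected step is a 2.2-fold lower number from compound 1 to compound 4 (0.33 log units; beyond the scatter). For compound 4 the estimated value is 6500 nM, with an expected range of 2500 nM to 17000 nM.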

Compound 4, half-maximal cytotoxic concentration: 17000 nM
Compound 4: middle estimate off by 2.6-fold (0.42 log units), on the low side; the range from low to high includes it.
By their numbers in this assay, from the lowest: compounds 1, 3, 4 and 2 (each within the scatter of the next, the first and the last beyond it).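

In this assay the group with 2 six-membered non-aromatic rings, 10 heavy atoms and 2 defined stereocentres, placed on a saturated chain carbon bound to a nitrogen on an aromatic ring in place of 2-(dimethylamino)ethyl, gives a 1.2-fold higher number from compound 1 to compound 4 (0.08 log units; within the scatter) and leaves the two compounds level. Among these compounds, this is the first reading at this position, and it shows that going from an open group of 5 heavy atoms to this larger ring-bearing group, each with 1 hydrogen-bond acceptor and no net charge, does not separate compound 4 from compound 1 in this read-out. No supporting measurement bears on why the two stand level.

Among the compounds shown here, the series holds only one ring-bearing group at this place and only one arrangement of its 2 defined stereocentres, so the part played by that arrangement stays open. Also open, on these data alone, is whether a longer chain ending in dimethylamino, or a carboxylic acid at this place, would stay level with compound 1 in this assay, and whether the level result would hold without the trifluoromethyl group.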